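The source may hold more compounds than are shown below. What is called first, only, known or untested is meant among the compounds shown, and "the series" means these compounds.

Of the compounds shown here, three built on the same core have been tested in an assay on isolated protein for inhibition of DNA topoisomerase 1 (Homo sapiens), with a stated time of 30 min, tested at 100 uM; on this read-out higher numbers stand for more inhibition at the one concentration tested (going by the name of the read-out) and lower numbers for less inhibition. Compound 1 `Oc1ccc(-c2cc(-c3cccc(O)c3)nc(-c3ccccc3O)c2)cc1` gives 1.5%. Compound 2 `Oc1ccc(-c2cc(-c3cccc(O)c3)nc(-c3cccc(O)c3)c2)cc1` gives 0%, and compound 3 `Oc1ccc(-c2cc(-c3ccccc3O)nc(-c3ccccc3O)c2)cc1` gives 3.7%. Compound 2 carries the smallest of the three numbers, yet the steps of a number 1.5 percentage points lower from compound 1 to compound 2 (within the scatter) and a number 2.2 percentage points higher from compound 1 to compound 3 (within the scatter) are both within the scatter, so the three numbers cannot be told apart.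

Compound 4 `Oc1cccc(-c2cc(-c3ccccc3O)cc(-c3cccc(O)c3)n2)c1` has not yet been tested in this assay. Against compound 2 it differs in one place: 2-hydroxyphenyl in place of 4-hydroxyphenyl on an aromatic carbon, sitting on an aromatic carbon of a six-membered aromatic ring with 1 nitrogen, opposite the ring nitrogen. The two measured steps that bear on this are rearrangements of a hydroxyphenyl group of the same kind, and each stayed within the scatter, so no step beyond the scatter is expected here either. For compound 4 the number in this assay is estimated at 2%, in a range from 0% to 10%. The step this estimate implies, a number 2 percentage points higher from compound 2 to compound 4 (within the scatter), is expected to stay within the scatter.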

Compound 4, a percentage reported as inhibition, at one concentration (the size of the read-out at that concentration, not a potency): 0%
Compound 4: the middle estimate sits 2 percentage points above what was measured, within the range that was stated.
By their numbers in this assay, from the lowest: compounds 2, 4, 1 and 3 (each within the scatter of the next).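

In this assay, for the compounds shown here, the step of no change at the digits printed from compound 2 to compound 4 (within the scatter) is the first reading of a change at the position opposite the ring nitrogen, where compounds 1, 2 and 3 all carry 4-hydroxyphenyl. It shows that 2-hydroxyphenyl can take the place of 4-hydroxyphenyl there without a step beyond the scatter, so this position joins the other rearrangements of hydroxyphenyl groups on the shared core, none of which separated the compounds. Nothing at hand explains this result.

The compounds shown carry only hydroxyphenyl groups, so they leave open whether any other group at this position would produce a step beyond the scatter. A methoxy group in place of the hydroxyl, or an amine or a carboxylic acid on that ring, remains an open case, as does the behaviour of these compounds at any other concentration.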